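Methyl in Place of Hydrogen on Selenium: Awaiting Compound 4

A few compounds are considered here, and "the series" means these few. Any claim that something is new, unique, unknown or untested is made for them only; others in the source may bear on it.

Three compounds built on one shared core have been examined in a functional assay on HT-29 cells (Homo sapiens) for cytotoxicity, read by MTT assay, with a stated time of 72 h; a higher number here means a weaker inhibitor of growth, a lower number a stronger inhibitor of growth. Compound 1 `COc1ccc(CNc2nc([Se]C)nc3ccccc23)cc1` reached only the limit of the assay, giving > 100000 nM. Compound 2 `CCCCC[Se]c1nc(NCc2ccccc2)c2ccccc2n1` likewise returned the limit, > 100000 nM. Compound 3 `[SeH]c1nc(NCc2ccccc2)c2ccccc2n1` also came back at the limit, > 100000 nM. Among the measured compounds shown here, the single one-point comparison among them, a step that the two limits leave unreadable from compound 2 to compound 3, therefore cannot be read in size or direction, and all that can be said of compound 3 is that it stands at the limit together with the other two: the limit of > 100000 nM in this assay, at which 3 of the 3 values shown sit.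

The next compound, compound 4 `C[Se]c1nc(NCc2ccccc2)c2ccccc2n1`, differs from compound 3 in one place: methyl in place of hydrogen on a selenium. For the measured compounds named here, no measured step bears directly on this change, since the one step that exists is hidden by the limits on both of its sides. With every value shown sitting at the limit, no step beyond the usual scatter can be expected in this assay in either direction. Compound 4 is therefore expected to sit at or near the limit as well, around 150000 nM, with a range from 30000 nM to 500000 nM. For compound 4 this estimate amounts to an expected step that the limit leaves unreadable from compound 3 to compound 4, that is, no change the assay could resolve. How compound 4 in fact behaves must await its measurement.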

Compound 4, concentration for total growth inhibition: 81000 nM
Estimate against measurement, compound 4: 1.9-fold (0.27 log units) above; measured number inside the range.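

Methyl on a selenium whose other neighbour is an aromatic carbon gives the only number in this assay that is not a limit, and the change from hydrogen reads as an at least 1.2-fold lower number from compound 3 to compound 4 (0.09 log units; that floor lies within the scatter). Hydrogen in place of butyl on a saturated chain carbon bound to a selenium atom gives an at least 1.2-fold lower number from compound 2 to compound 4 (0.09 log units; that floor lies within the scatter), and hydrogen in place of methoxy on an aromatic carbon gives an at least 1.2-fold lower number from compound 1 to compound 4 (0.09 log units; that floor lies within the scatter). All three steps are floors that do not pass the usual scatter, so the position shows at most a first hint of a readable value, and the series still rests mainly on one boundary: the limit of > 100000 nM in this assay, at which 3 of the 4 values shown sit.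

As far as these compounds go, the true size of each step stays open, and so does whether the selenium position can carry a value well clear of the limit at all. Whether an ethyl group, a chain ending in an amine or a carboxylic acid on the selenium, or a methoxy on the aromatic ring with the methyl kept in some other setting would move the number further, the compounds shown cannot tell.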